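Carbamate for Morpholine on the Propoxy Chain

The compounds below may be only part of what the source reports. "The series", "measured", "known", "first", "only" and "open" are said of these compounds alone.

Among the measured compounds shown here, compound 3 `COc1cc2ncnc(-n3nc(-c4ccccn4)nc3N)c2cc1OCCCN1CC(C)OC(C)C1` is the only member of this set that returns a number in an assay on MCF7 cells for inhibition of Serine-protein kinase ATM (Homo sapiens), read by immunofluorescence, with a stated time of 1 h; on this read-out lower numbers stand for stronger inhibition and higher numbers for weaker inhibition: compound 3 gives 1600 nM. Compound 1 `Nc1nc(-c2ccccn2)nn1-c1ncnc2cc(OC(F)(F)F)ccc12` reaches only the limit of this assay, > 40000 nM. Compound 2 `COc1cc2ncnc(Nc3ccccn3)c2cc1OC` likewise stops at the limit, > 40000 nM. For the measured compounds named here, those two values sit at the limit of > 40000 nM in this assay, at which 2 of the 3 values shown sit, so no step between measured compounds can be stated, and nothing in the measured set shows how a change on the propyl chain moves the read-out.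

Compound 4 `COc1cc2ncnc(-n3nc(-c4ccccn4)nc3N)c2cc1OCCCNC(=O)OC(C)C` differs from compound 3 in one place: (isopropoxycarbonyl)amino in place of 2,6-dimethylmorpholin-4-yl on a saturated chain carbon, three bonds along the chain from an oxygen on an aromatic ring. The rest of the molecule is unchanged.

Going by the values given here, with no measured step of this kind to lean on, the expectation is a modest weakening, small enough that it may not clear the usual scatter; the step is expected to read a 1.8-fold higher number from compound 3 to compound 4 (0.24 log units; within the scatter). Compound 4 is accordingly estimated at 2800 nM, with a plausible range from 800 nM to 10000 nM.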

Compound 4, half-maximal inhibitory concentration: 1000 nM
Compound 4: the middle estimate sits 2.8-fold (0.45 log units) above what was measured, within the range that was stated.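

In this assay the change reads a 1.6-fold lower number from compound 3 to compound 4 (0.20 log units; within the scatter), so on this saturated chain carbon the open-chain (isopropoxycarbonyl)amino group, which brings a hydrogen-bond donor and no ring, stands level with the 2,6-dimethylmorpholin-4-yl ring. Among the compounds shown here, this is the first readable step in the set, and it shows that the read-out at this position does not depend on keeping the ring, at least for this one carbamate. Nothing measured here accounts for the step.

Steps to compound 1 and compound 2 cannot be read: the limit of > 40000 nM in this assay, at which 2 of the 4 values shown sit. On these data alone, it remains open whether a primary amine, a carboxylic acid or a longer chain in place of the carbamate would hold the read-out at the level shared by compound 3 and compound 4, or move it beyond the scatter.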